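A few compounds are considered here, and "the series" means these few. Any claim that something is new, unique, unknown or untested is made for them only; others in the source may bear on it.

Working notes on the series. Compound 3 `Cc1nc(-c2ccccc2)sc1C(=O)CSc1nc(N)c(C#N)c(-c2ccccc2)n1` and compound 1 `COc1ccc(-c2nc(SCC(=O)c3sc(-c4ccccc4)nc3C)nc(N)c2C#N)cc1` share one core and differ only by methoxy in place of hydrogen on an aromatic carbon. In a functional assay on U-87MG ATCC cells for antiproliferative activity against U-87 MG (Homo sapiens), read by MTT assay, with a stated time of 48 h, tested at 50 uM (a higher number here means a weaker effect of the compound at the concentration tested, a lower number a stronger effect), compound 3 gives 26.3% and compound 1 gives 33.8%; the step of a number 7.5 percentage points higher from compound 3 to compound 1 (within the scatter) lies within the scatter, so the two numbers cannot be ordered against each other. Compound 2 `Cc1nc(-c2ccccc2)sc1C(=O)CSc1nc(-c2ccc(Cl)c(Cl)c2)c(C#N)c(=O)[nH]1` is built on a different core; the difference between the core of compound 2 and the core of compound 3 is not broken down here. In this assay compound 2 gives 75.3%, the highest of the three numbers and beyond the scatter from both compound 1 and compound 3, so at this concentration compound 2 is the weakest of the three.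

Compound 4 `COc1ccc(-c2nc(C)c(C(=O)CSc3nc(-c4ccc(Cl)c(Cl)c4)c(C#N)c(=O)[nH]3)s2)cc1` has not yet been measured. It differs from compound 2 by methoxy in place of hydrogen on an aromatic carbon, the same change as that made from compound 3 to compound 1, at the same kind of place described in the same words. Among the compounds shown this change occurs twice in all. Among the compounds with values here, its one measured instance, a number 7.5 percentage points higher from compound 3 to compound 1 (within the scatter), stayed within the scatter on the other core. On that basis the step of a number 3.7 percentage points higher from compound 2 to compound 4 (within the scatter) is expected to be small as well. That expectation rests on a single pair, the step of a number 7.5 percentage points higher from compound 3 to compound 1 (within the scatter), measured on a different core, so the range is kept wide. In this assay compound 4 is estimated at 79%, with a range from 62% to 92%.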

Compound 4, a percentage reported as activity, at one concentration (the size of the read-out at that concentration, not a potency): 78.4%
Beside the measured number, compound 4's estimate is 0.6 percentage points above it; the measured number falls inside the stated range.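

In this assay the change from phenyl to 4-methoxyphenyl gives a number 3.1 percentage points higher from compound 2 to compound 4 (within the scatter), and the two instances of this change cannot be told apart: the same change on two cores in this assay, a number 7.5 percentage points higher (within the scatter) from compound 3 to compound 1 and a number 3.1 percentage points higher (within the scatter) from compound 2 to compound 4, 4.4 percentage points apart, within the scatter of two such steps

Within these two pairs, then, methoxy in place of hydrogen on an aromatic carbon, para to a large group, gives a step within the scatter on both the core of compound 3 and the core of compound 2, so the small step seen on one core also holds on the other. This does not show that methoxy is without any effect, since a real difference smaller than the scatter would go unseen, and two pairs read at a single concentration in one cell line say nothing about other cores, about the effect at other concentrations, or about other assays.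

From the compounds shown here alone, it remains open whether a different group at the same place, such as an amine, a carboxylic acid or a longer chain like butoxy, would also give a step within the scatter on both cores. It also remains open which of the features separating the core of compound 2 from the core of compound 3 accounts for the gap between their numbers, since those two compounds differ in more than one place.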